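Trifluoromethyl for chloro in a small antiproliferative series

The source may report more compounds than this note shows. Statements on the series, on what has been measured and on what is new or still open speak of the compounds shown alone.

In a functional assay on A549 cells (Homo sapiens) for antiproliferative activity, read by MTT assay, with a stated time of 24 h (a lower number here means a stronger inhibitor, a higher number a weaker inhibitor), compound 3 (`O=S(=O)(c1ccc(Cl)cc1)n1c(-c2cn(-c3ccccc3)nc2-c2ccc(C(F)(F)F)cc2)nc2ccccc21`) gives 2560 nM as its reading. Compound 1 (`O=S(=O)(c1ccc(C(F)(F)F)cc1)n1c(-c2cn(-c3ccccc3)nc2-c2ccc(F)cc2)nc2ccccc21`) gives 1280 nM on the same read-out, a number within the scatter of compound 3. Going by the values given here, compound 2 (`O=[N+]([O-])c1ccc(S(=O)(=O)n2c(-c3cn(-c4ccccc4)nc3-c3ccc(C(F)(F)F)cc3)nc3ccccc32)cc1`) stands apart at 790 nM and is the only compound separated from compound 3 by more than the scatter. Compound 4 (`O=S(=O)(c1ccc(C(F)(F)F)cc1)n1c(-c2cn(-c3ccccc3)nc2-c2ccc(C(F)(F)F)cc2)nc2ccccc21`) has not yet been measured. It differs from compound 3 by trifluoromethyl in place of chloro on an aromatic carbon, para to a large group, and the change counts as trifluoromethyl in place of chloro on an aromatic carbon in full.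

Among the compounds with values here, no measured step covers this exact swap. The nearest evidence is a 3.2-fold higher number from compound 2 to compound 3 (0.51 log units; beyond the scatter) for chloro in place of nitro at the same place, a modest move. Compound 1 at 1280 nM already carries the 4-(trifluoromethyl)phenyl group there, but it differs from compound 4 elsewhere and so offers only a loose guide. A slightly lower number than for compound 3 is therefore expected, though no step beyond the scatter is anticipated. The estimated move is a 1.4-fold lower number from compound 3 to compound 4 (0.15 log units; within the scatter) in this assay for this swap. For compound 4 the expected value is 1800 nM with an estimated range of 800 nM to 4000 nM in this assay.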

Compound 4, half-maximal inhibitory concentration: 860 nM
The estimate for compound 4 lay 2.1-fold (0.32 log units) above the measured number, and the stated range covers the measured number.
By their numbers in this assay, from the lowest: compounds 2, 4, 1 and 3 (each within the scatter of the next, the first and the last beyond it).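

In this assay, the change from 4-chlorophenyl to 4-(trifluoromethyl)phenyl gives a 3.0-fold lower number from compound 3 to compound 4 (0.47 log units; beyond the scatter), the first step read for this swap, and it lies beyond the scatter. Among the three groups seen at this place, chloro therefore stands apart from both of the others, while trifluoromethyl and nitro cannot be told apart, with a 1.1-fold higher number from compound 2 to compound 4 (0.04 log units; within the scatter). At the other place where a group changes, trifluoromethyl in place of fluoro gives a 1.5-fold lower number from compound 1 to compound 4 (0.17 log units; within the scatter), so that single step separates the two groups no more than repeated measurements would.

Nothing on hand offers an explanation for these readings. Going by these compounds, it remains open whether an amine, a carboxylic acid or a methoxy group at the position held by chloro would read with nitro and trifluoromethyl or with chloro, and whether the same order of groups would hold with a different group at the other aromatic position.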